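This account rests on a few compounds, and the source may have more. Where it says the series, first, only, none or still open, it means among the compounds named here.

Measured so far in a functional assay on isolated protein for agonist activity at Free fatty acid receptor 1 (Homo sapiens), read by HTRF and inositol phosphate accumulation, with a stated time of 60 min; a higher number here means that more compound is needed for the effect, a lower number that less compound is needed:

compound 1 `CCOc1ccc(Cl)c(-c2ccc(OCCCC(=O)O)cc2)c1` — 1130 nM
compound 2 `O=C(O)CCCOc1ccc(-c2ccccc2C(F)(F)F)cc1` — > 9950 nM
compound 3 `O=C(O)CCCOc1ccc(-c2cc(-[n+]3ccsc3)ccc2Cl)cc1` — > 9950 nM

Compound 3 in this assay gives > 9950 nM, which is a limit of the assay and not a number. Compound 2 likewise gives only a limit, > 9950 nM. Two of the three values sit at that limit (the limit of > 9950 nM in this assay, at which 2 of the 3 values shown sit), so compound 3 can only be placed at or beyond it.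

Compound 4 `O=C(O)CCCOc1ccc(-c2cc(Oc3cccc(F)c3)ccc2Cl)cc1` carries a group of 8 heavy atoms (6 carbon, 1 oxygen, 1 fluorine; one six-membered aromatic ring of carbon only) in place of a group of 5 heavy atoms (3 carbon, 1 nitrogen, 1 sulfur; one five-membered aromatic ring with 2 hetero atoms), on an aromatic carbon. Among the measured compounds shown here, the one measured step that bears on this position is an at least 8.8-fold higher number from compound 1 to compound 3 (0.94 log units; beyond the scatter), where the charged five-membered ring entered; it was beyond the scatter and cost activity. Compound 4 removes that ring again, so a return towards the range of compound 1 is expected, with an estimated step of an at least 6.6-fold lower number from compound 3 to compound 4 (0.82 log units; beyond the scatter). Compound 4 is expected at about 1500 nM (range 300 nM to 8000 nM).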

Compound 4, half-maximal effective concentration: 3350 nM
Beside the measured number, compound 4's estimate is 2.2-fold (0.35 log units) below it; the measured number falls inside the stated range.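

Compound 3 stands only at a limit of the assay: the limit of > 9950 nM in this assay, at which 2 of the 4 values shown sit. At this position, para to a chloro group, 3-fluorophenoxy in place of the charged five-membered ring brings a measurable value, with an at least 2.9-fold lower number from compound 3 to compound 4 (0.47 log units; beyond the scatter). A large aromatic group on the oxygen is therefore compatible with activity, though 3-fluorophenyl in place of ethyl is not neutral for it, with a 3.0-fold higher number from compound 1 to compound 4 (0.47 log units; beyond the scatter).

As far as these compounds go, whether the fluorine contributes remains open, as no plain phenoxy stands beside compound 4. Also open, from the compounds shown here alone, is how a smaller methoxy group or an amine at this position would compare with compound 1.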